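Acetyl on the Amine of Compound 2

A few compounds are considered here, and "the series" means these few. Any claim that something is new, unique, unknown or untested is made for them only; others in the source may bear on it.

Measured in an ADME assay on Caco-2 cells (Homo sapiens) for permeability, read by LC-MS, in the apical to basolateral direction, with a stated time of 120 min, tested at 50 uM; a higher number here means that the compound crosses the layer faster, a lower number that the compound crosses the layer more slowly:
Compound 1 `COCCNc1nonc1/C(=N/O)Nc1ccc(F)c(Br)c1`: 44 10^-6 cm/s
Compound 2 `NCCNc1nonc1/C(=N/O)Nc1ccc(F)c(Br)c1`: 1.8 10^-6 cm/s

Of the two, compound 2 stands lowest at 1.8 10^-6 cm/s, and compound 1 lies higher at 44 10^-6 cm/s. Compound 3 `CC(=O)NCCNc1nonc1/C(=N/O)Nc1ccc(F)c(Br)c1` has acetyl in place of hydrogen on an amine nitrogen of compound 2, which turns 2-aminoethyl into 2-acetamidoethyl: acetyl in place of hydrogen on an amine nitrogen. Within the data shown here, one measured step bears on this change: a 24-fold lower number from compound 1 to compound 2 (1.39 log units; beyond the scatter), with amino in place of methoxy on a saturated chain carbon. That step is large and beyond the scatter. Among the measured compounds shown here, compound 3 matches neither end of it, and no acetamido compound has been measured, so the size remains uncertain. A partial return towards compound 1 is expected in this assay. The expected change is a 4.4-fold higher number from compound 2 to compound 3 (0.65 log units; beyond the scatter), a moderate rise. For compound 3 the estimated value is 8 10^-6 cm/s, with an expected range of 2.5 10^-6 cm/s to 25 10^-6 cm/s.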

Compound 3, apparent permeability: 19 10^-6 cm/s
Compound 3: middle estimate off by 2.4-fold (0.38 log units), on the low side; the measured number falls inside the stated range.
By their numbers in this assay, from the lowest: compound 2; then compound 3; then compound 1.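

In this assay, putting acetyl on the amine nitrogen gives an 11-fold higher number from compound 2 to compound 3 (1.02 log units; beyond the scatter) and so shows that the low number of compound 2 does not carry over to every chain with a nitrogen at this place. The return is not complete, since acetamido in place of methoxy gives a 2.3-fold lower number from compound 1 to compound 3 (0.36 log units; beyond the scatter) and leaves 2-acetamidoethyl modestly short of the methoxy chain, though beyond the scatter. Nothing shown here accounts for either step.

Going by these compounds, it remains open whether the rise is particular to acetyl or would also come with a methanesulfonyl group or a urea on the same nitrogen. On these data alone, how a dimethylamino group, a carboxylic acid or a longer chain at this place would read in this assay also stays unknown.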